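Series notes: amine swap on the shared core

The compounds below may be only part of what the source reports. "The series", "measured", "known", "first", "only" and "open" are said of these compounds alone.

In a functional assay on L02 cells (Homo sapiens) for inhibition, read by Griess assay, with stated times of 1 h and 24 h (on this read-out higher numbers stand for weaker inhibition and lower numbers for stronger inhibition), compound 2 `COc1cc(/C=C/c2nc(N(C)C)c3sccc3n2)cc(OC)c1OC` gives > 1000000 nM, which is a limit of the assay rather than a number. Compound 1 `COc1cccc(CNc2nc(/C=C/c3ccccc3)nc3ccsc23)c1` likewise gives > 1000000 nM in this assay, again a limit. Both values shown sit at the limit of > 1000000 nM in this assay, at which 2 of the 2 values shown sit, so no potency has yet been resolved in this set. Compound 3 `COc1ccc(CNc2nc(/C=C/c3cc(OC)c(OC)c(OC)c3)nc3ccsc23)cc1` is not yet measured; it differs from compound 2 by (4-methoxybenzyl)amino in place of dimethylamino on an aromatic carbon. Among the compounds with values here, with no measured step between compounds in the set, the expected step from compound 2 to compound 3 is a number no higher from compound 2 to compound 3 (the limit leaves the size open), nothing beyond the scatter. Compound 3 is therefore estimated at 1000000 nM, within 300000 nM to 3000000 nM, and is most likely reported again as a limit.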

Compound 3, half-maximal inhibitory concentration: > 1000000 nM
Compound 3 ended at the assay's limit (the forecaster's own chance of this, stated with the estimate: 75%); the middle value lies on the limit itself.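

No step can be read between compound 2 and compound 3, as both values are limits rather than numbers: the limit of > 1000000 nM in this assay, at which 3 of the 3 values shown sit.

The compounds shown leave open whether swapping the amine on the shared core changes inhibition at all.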